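The source may report more compounds than this note shows. Statements on the series, on what has been measured and on what is new or still open speak of the compounds shown alone.

The series consists of three measured compounds and one that awaits measurement. Compound 1 `Oc1ccc(-c2nc3cc(C(F)(F)F)ccc3[nH]2)cc1` gives 17000 nM in an ADME assay on MT4 cells (Homo sapiens) for cytotoxicity, read by MTT assay, with a stated time of 96 h (a lower number here means that less compound is tolerated, a higher number that more compound is tolerated), and compound 2 `Nc1ccc(-c2nc3cc(Cl)c(Cl)cc3[nH]2)cc1` gives 17000 nM in this assay. Compound 3 `O=[N+]([O-])c1ccc(-c2nc3cc(C(F)(F)F)ccc3n2C2CCCCC2)cc1` gives 49000 nM in this assay, the highest of the three numbers, so it is the compound that the cells tolerate best; its number lies beyond the scatter of both the other two, and compound 1 and compound 2 themselves give matching values.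

Compound 4 `CCC(=O)Nc1ccc(-c2nc3cc(C(F)(F)F)ccc3n2C2CCCCC2)cc1` is the unmeasured member. It differs from compound 3 in one place: propanoylamino in place of nitro on an aromatic carbon. Among the measured compounds shown here, no step between two measured compounds reproduces this change, so there is nothing in the measured data that tells how this kind of exchange shifts tolerance in this assay.

Given that, compound 4 is expected to stay close to compound 3, with the step of a 1.2-fold lower number from compound 3 to compound 4 (0.09 log units; within the scatter) estimated to fall within the scatter. The tolerance of compound 4 in this assay is therefore estimated at 40000 nM, within a range of 15000 nM to 100000 nM.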

Compound 4, half-maximal cytotoxic concentration: 17000 nM
Estimate against measurement, compound 4: 2.4-fold (0.37 log units) above, within the range that was stated.
By their numbers in this assay, from the lowest: compounds 1, 2 and 4 (each within the scatter of the next); then compound 3.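

At the aromatic carbon para to a large group, the exchange of nitro for propanoylamino gives the series its first step between two compounds that differ in one place: in this assay it is a 2.9-fold lower number from compound 3 to compound 4 (0.46 log units; beyond the scatter). This shows that tolerance responds to what sits at this position, and that with propanoylamino there the cells tolerate less compound than with nitro, although the step is modest. No measurement at hand bears on why the number shifts.

What the compounds shown leave open is whether a free amine, an acetylamino group or a longer acyl chain at this same position would give a number nearer that of compound 3 or that of compound 4. As far as these compounds go, it also remains open whether the same exchange would give a step of similar size on another core.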